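Dimethylsulfamoyl in Place of a Hydroxypyrrolidine Sulfonamide

The compounds below may be only part of what the source reports. "The series", "measured", "known", "first", "only" and "open" are said of these compounds alone.

Measured so far:
Compound 1, `O=C([C@@H]1CCCN(S(=O)(=O)c2ccc(S(=O)(=O)N3CC[C@H](O)C3)cc2)C1)N1CCC(F)(F)CC1`: 580 nM
Compound 2, `CCN(CC)S(=O)(=O)c1ccc(S(=O)(=O)N2CCC[C@@H](C(=O)N3CC[C@@H](OC)C3)C2)cc1`: 11500 nM
Compound 3, `CCN(CC)S(=O)(=O)c1ccc(S(=O)(=O)N2CCC[C@@H](C(=O)N3CCC(C(F)F)CC3)C2)cc1`: 450 nM

All three were tested in a functional assay on BXPC-3 cells (Homo sapiens) for inhibition, read by MTT assay, with a stated time of 7 days; on this read-out lower numbers stand for stronger inhibition and higher numbers for weaker inhibition. Compound 1 holds the second highest of the three numbers; compound 1 and compound 3 sit within the scatter of each other, while compound 2 lies well above both. Among the compounds with values here, the one step between compounds that differ in a single place, a 26-fold lower number from compound 2 to compound 3 (1.41 log units; beyond the scatter), concerns the ring attached to the carbonyl carbon and is large.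

Compound 4, `CN(C)S(=O)(=O)c1ccc(S(=O)(=O)N2CCC[C@@H](C(=O)N3CCC(F)(F)CC3)C2)cc1`, is not yet measured. Relative to compound 1 it differs as follows: dimethylamino in place of 3-hydroxypyrrolidin-1-yl on a sulfonyl sulfur. Within the data shown here, this change sits on the sulfonyl sulfur, the opposite end of the shared core from where the large step was seen, and no measured pair isolates a change at that position. Compound 1 and compound 3 differ at the sulfonyl sulfur as well as at the carbonyl side, yet their numbers fall within the scatter, which hints that the sulfonyl end tolerates variation.

Compound 4 is therefore expected to give about 650 nM in this assay, within 250 nM to 1700 nM, a step of a 1.1-fold higher number from compound 1 to compound 4 (0.05 log units; within the scatter) that is expected to stay within the scatter.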

Compound 4, half-maximal inhibitory concentration: 560 nM
Estimate against measurement, compound 4: 1.2-fold (0.06 log units) above, within the range that was stated.
By their numbers in this assay, from the lowest: compounds 3, 4 and 1 (each within the scatter of the next); then compound 2.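

In this assay, within the data shown here, putting dimethylamino in place of 3-hydroxypyrrolidin-1-yl on a sulfonyl sulfur gives a 1.0-fold lower number from compound 1 to compound 4 (0.02 log units; within the scatter), and this is the first pair here that isolates a change at that position. With the carbonyl side held fixed, the ring, the defined stereocentre and the hydrogen-bond donor of 3-hydroxypyrrolidin-1-yl can all be lost with no difference beyond the scatter, which turns the earlier hint from two compounds differing in more than one place into a direct comparison. Nothing measured here speaks to why this exchange leaves the read-out where it was.

The compounds shown leave open how far this tolerance reaches, since a morpholine, a piperazine or a group bearing a carboxylic acid on the same sulfonyl sulfur could give a quite different number. Among these compounds, they also leave open whether the same exchange would read the same with another group on the carbonyl carbon, such as the 3-methoxypyrrolidin-1-yl of compound 2, because this single pair carries only one group there.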